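This account rests on a few compounds, and the source may have more. Where it says the series, first, only, none or still open, it means among the compounds named here.

Of the compounds shown here, three have been measured in an ADME assay on cells (Hepatocyte, Rattus norvegicus) for metabolic stability; on this read-out higher numbers stand for fast clearance and lower numbers for slow clearance. Compound 1 `Cc1ccc2[nH]c(C(=O)N[C@H]3CN(S(=O)(=O)C4CCOCC4)C[C@@H]3C(=O)NCCN(C)C)cc2c1` gives 4 uL/min, compound 2 `Cc1nc(-c2cccc(C(F)(F)F)c2)sc1C(=O)N[C@H]1CN(S(=O)(=O)c2ccccc2)C[C@@H]1C(=O)N[C@H]1CCCNC1` gives 2.9 uL/min, and compound 3 `O=C(N[C@H]1CN(S(=O)(=O)c2ccccc2)C[C@@H]1C(=O)N1C[C@H]2CCNC[C@H]21)c1cc(-c2ccccc2Cl)on1` gives 4.7 uL/min. All three numbers lie within the usual scatter of one another, so none can be set apart; the number for compound 3 simply sits at the upper edge of that narrow band. Compound 4 `CN(C(=O)[C@H]1CN(S(=O)(=O)c2ccccc2)C[C@@H]1NC(=O)c1cc(-c2ccccc2Cl)on1)[C@H]1CCCNC1` has not yet been measured. It differs from compound 3 by a group of 8 heavy atoms (6 carbon, 2 nitrogen; one six-membered non-aromatic ring with 1 hetero atom) in place of a group of 8 heavy atoms (6 carbon, 2 nitrogen; one four-membered non-aromatic ring with 1 hetero atom, one six-membered non-aromatic ring with 1 hetero atom), on a carbonyl carbon. The measured compounds differ widely in their other parts yet give similar numbers; on that basis no step beyond the scatter is expected here. Compound 4 is therefore expected to give 5 uL/min, with a likely range from 2.5 uL/min to 10 uL/min. The step of a 1.1-fold higher number from compound 3 to compound 4 (0.03 log units; within the scatter) that this estimate means is expected to stay inside the scatter.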

Compound 4, intrinsic clearance in a liver preparation (reported as CLH), per the amount of preparation that the assay uses: 5.8 uL/min
For compound 4 the middle estimate is 1.2-fold (0.06 log units) below the measured one; the measured number falls inside the stated range.
By their numbers in this assay, from the lowest: compounds 2, 1, 3 and 4 (each within the scatter of the next).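

Putting the group with only a six-membered ring in place of the group with a four-membered and a six-membered ring on this carbonyl carbon gives a 1.2-fold higher number from compound 3 to compound 4 (0.09 log units; within the scatter) in this assay. At this position, then, the four-membered ring and one defined stereocentre can go without a step beyond the scatter. No measurement here offers a reason for this result. Still open, from the compounds shown here alone, is whether a different kind of group on this carbonyl carbon, such as a carboxylic acid, would move the number beyond the scatter.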